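This account rests on a few compounds, and the source may have more. Where it says the series, first, only, none or still open, it means among the compounds named here.

Working notes on the series.

Compound 2 `Nc1ccccc1NC(=O)CCCCCCc1nc(-c2ccccc2Cl)no1` is the reference point here. In an assay on isolated protein for inhibition of histone deacetylase 8 (Homo sapiens), read by fluorescence, with a stated time of 10 min (a higher number here means a weaker inhibitor, a lower number a stronger inhibitor), compound 2 gives > 10000 nM, which is a limit of the assay and not a number. Its nearest measured relative is compound 1 `Nc1ccccc1NC(=O)CCCCCCc1nc(-c2ccccc2)no1`, which carries hydrogen where compound 2 carries chloro on an aromatic carbon. In this assay compound 1 gives > 10000 nM, again a limit rather than a number. The step that the two limits leave unreadable from compound 1 to compound 2 therefore cannot be read from the two values, and the limit of > 10000 nM in this assay, at which 2 of the 2 values shown sit, is the whole of what the measured pair offers: both values sit at the same limit, and no direction or size can be drawn from them.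

The next compound, compound 3 `Nc1ccccc1NC(=O)CCCCCCc1nc(-c2ccc([N+](=O)[O-])cc2)no1`, differs from compound 2 by 4-nitrophenyl in place of 2-chlorophenyl on an aromatic carbon. For the measured compounds named here, no measured step bears on this change; the only measured step, from compound 1 to compound 2, is itself unreadable. The expectation for compound 3 is therefore carried by the limit at which compound 2 sits, and the step that the limit leaves unreadable from compound 2 to compound 3 is estimated to be none beyond the scatter. Compound 3 is expected to give about 15000 nM in this assay, within a range of 3000 nM to 60000 nM, and most likely to be reported as a limit once more.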

Compound 3, half-maximal inhibitory concentration: > 10000 nM
Compound 3: only a limit was reported (the forecaster's own chance of this, stated with the estimate: 75%); the middle value lies beyond the limit too.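

In this assay compound 3 gives > 10000 nM, again a limit of the assay and not a number. The steps linking compound 1, compound 2 and compound 3 therefore cannot be read, and only the shared limit stands: the limit of > 10000 nM in this assay, at which 3 of the 3 values shown sit. Left open is how these three compounds compare in strength of inhibition.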